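Swapping a dimethoxyphenyl for a methylphenyl on the shared core

The source may report more compounds than this note shows. Statements on the series, on what has been measured and on what is new or still open speak of the compounds shown alone.

Measured compounds:
- compound 1, `COc1ccccc1N1C(=O)C(C)SC1c1cccc(C(=O)NCCCCc2ccccc2)c1`, 38%
- compound 2, `COc1ccc(OC)c(N2C(=O)CSC2c2cccc(C(=O)NCCCCc3ccccc3)c2)c1`, 1%
- compound 3, `O=C(NCCCCc1ccccc1)c1cccc(C2SCC(=O)N2c2cccc(F)c2)c1`, 39%

In a functional assay on U2OS cells (Homo sapiens) for inhibition, read by CCK-8 assay, with a stated time of 72 h, tested at 1 uM (a higher number here means more inhibition at the concentration tested (going by the name of the read-out), a lower number less inhibition), compound 2 gives the lowest of the three numbers; the nearest measured value belongs to compound 1, which in this assay gives 38%, and compound 3 in this assay gives 39%. Both of these stand well beyond the scatter above compound 2.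

The unmeasured compound 4, `Cc1cccc(N2C(=O)CSC2c2cccc(C(=O)NCCCCc3ccccc3)c2)c1`, differs from compound 2 in one place: 3-methylphenyl in place of 2,5-dimethoxyphenyl on an amide-type nitrogen in a ring. For the measured compounds named here, only one measured step bears on this change, and it alters the same position: the step of a number 38 percentage points higher from compound 2 to compound 3 (beyond the scatter). There, replacing the 2,5-dimethoxyphenyl with a different small substituted phenyl raised the read-out by a large amount. Going by the values given here, a 3-methylphenyl is another small substituted phenyl with no hydrogen-bond acceptors, so a step of similar direction is expected for compound 4, though its exact size is uncertain because only one comparable step, a number 38 percentage points higher from compound 2 to compound 3 (beyond the scatter), is available.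

Compound 4 is therefore expected to show an upward step of a number 34 percentage points higher from compound 2 to compound 4 (beyond the scatter) in this assay. The estimate for compound 4 is 35%, with a range from 15% to 55%.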

Compound 4, a percentage reported as inhibition, at one concentration (the size of the read-out at that concentration, not a potency): 39%
Beside the measured number, compound 4's estimate is 4 percentage points below it; the range from low to high includes it.
By their numbers in this assay, from the lowest: compound 2; then compounds 1, 3 and 4 (each within the scatter of the next).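

In this assay, the second replacement on the amide-type nitrogen in a ring gives a large rise as well, a number 38 percentage points higher from compound 2 to compound 4 (beyond the scatter), so the earlier jump at this position is no longer tied to a single incoming group. The comparison between the two replacements shows no change at the digits printed from compound 3 to compound 4 (within the scatter): at this position on the shared core, the read-out does not separate a methyl from a fluoro on the aromatic ring, and among compounds 2, 3 and 4 only the 2,5-dimethoxyphenyl compound stands apart. Nothing measured here explains why these groups behave as they do.

The compounds shown do not tell whether removing one methoxy group from the 2,5-dimethoxyphenyl would be enough to restore the read-out, since compound 1 also differs from compound 2 by a methyl on the core. Also open, on these data alone, is how the read-out would respond to an amine or a carboxylic acid on this phenyl ring, and whether the rise seen at a single concentration would carry over to a full measure of potency.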